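Benzyl substitution on the lactam nitrogen of a dimethoxyphenyl series

The source may report more compounds than this note shows. Statements on the series, on what has been measured and on what is new or still open speak of the compounds shown alone.

Measured so far:
compound 1 `COc1cccc(OC)c1C1CCCC(=O)N1Cc1ccccc1` — 2420 nM
compound 2 `COc1cccc(OC)c1C1CCCC(=O)N1c1ccccc1` — > 10000 nM

Compound 1 stands as the only numeric result in a functional assay on CHO cells for antagonist activity at Orexin/Hypocretin receptor type 1 (Homo sapiens), read by FLIPR and calcium flux; a higher number here means a weaker inhibitor, a lower number a stronger inhibitor; the other entry is a limit. In this assay compound 2 reaches only the limit > 10000 nM, which is a limit of the assay and not a number. The step of an at least 4.1-fold higher number from compound 1 to compound 2 (0.61 log units; beyond the scatter) is therefore bounded from below by the limit of > 10000 nM in this assay, at which 1 of the 2 values shown sits.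

Compound 3 `COc1cccc(OC)c1C1CCCC(=O)N1Cc1cccc(OC(F)(F)F)c1` keeps the benzyl of compound 1 and differs from it by trifluoromethoxy in place of hydrogen on an aromatic carbon. Among the measured compounds shown here, no measured step touches a substituent on the benzyl ring; the only recorded step concerns phenyl in place of benzyl and does not bear on this change. The expected step is therefore a 1.6-fold lower number from compound 1 to compound 3 (0.21 log units; within the scatter), not clearly beyond the scatter. For compound 3 the estimate in this assay is 1500 nM, expected to fall between 500 nM and 5000 nM.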

Compound 3, half-maximal inhibitory concentration: 136 nM
Estimate against measurement, compound 3: 11-fold (1.04 log units) above, outside the stated range (below it).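

In this assay the benzyl ring of compound 1 turns out to be a responsive place: trifluoromethoxy on an aromatic carbon of that ring, meta to a large group, gives an 18-fold lower number from compound 1 to compound 3 (1.25 log units; beyond the scatter). Among the compounds shown here, the only earlier step replaced the benzyl as a whole and ended at a limit of the assay, whereas this one has a number at both ends and runs towards a stronger inhibitor, so the benzyl ring can take a substituent of 5 heavy atoms without loss. Nothing at hand accounts for the size of this step.

From the compounds shown here alone, whether the step belongs to trifluoromethoxy itself, or would also come with methoxy, chlorine or trifluoromethyl on the same carbon, stays open. Also open, going by these compounds, is how trifluoromethoxy would read on another carbon of the ring, and how an amine or a carboxylic acid would read there.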